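This account rests on a few compounds, and the source may have more. Where it says the series, first, only, none or still open, it means among the compounds named here.

In an ADME assay on A549 cells (Homo sapiens) for cytotoxicity, read by MTT assay (on this read-out higher numbers stand for lower toxicity in this test and lower numbers for higher toxicity in this test), compound 1 (`CCCCCCCCCCCCNc1ccn([C@H]2C[C@H](O)[C@@H](CO)O2)c(=O)n1`) gives 100000 nM as its reading. Among the measured compounds shown here, only one other compound has a number so far: compound 2 (`CCCCCCCCCCNc1nc(=O)n([C@H]2C[C@H](O)[C@@H](CO)O2)cc1C`) gives 156000 nM and the two values lie within the usual scatter of each other. Compound 3 (`CCCCCCCCCCCCNc1nc(=O)n([C@H]2C[C@H](O)[C@@H](CO)O2)cc1C`) differs from compound 1 by a single change (methyl in place of hydrogen on an aromatic carbon) in which methyl takes the place of hydrogen on an aromatic carbon. For the measured compounds named here, no measured pair shows this change on its own, so the data give no direct size for it. The only reference is the close agreement of the two readings so far, so no step beyond the scatter is expected in this assay in either direction. The expected step (a 1.2-fold higher number from compound 1 to compound 3 (0.08 log units; within the scatter)) is therefore small. Compound 3 is estimated at 120000 nM with an expected range from 55000 nM to 250000 nM in this test.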

Compound 3, half-maximal cytotoxic concentration: 158000 nM
Beside the measured number, compound 3's estimate is 1.3-fold (0.12 log units) below it; low and high end bracket the measured number.
By their numbers in this assay, from the lowest: compounds 1, 2 and 3 (each within the scatter of the next).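

In this assay, methyl in place of hydrogen on this aromatic carbon now has a measured size: the swap gives a 1.6-fold higher number from compound 1 to compound 3 (0.20 log units; within the scatter) and so does not separate the two compounds in this test. The other single change, ethyl in place of hydrogen on a saturated chain carbon, gives a 1.0-fold higher number from compound 2 to compound 3 (0.01 log units; within the scatter) and does not separate that pair either. Nothing at hand gives a reason for either result.

The compounds shown leave open whether chlorine or an amine on this aromatic carbon would give a step beyond the scatter. They also leave open whether a much shorter chain on the ring nitrogen-bearing amine, such as butyl, would do so.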